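A few compounds are considered here, and "the series" means these few. Any claim that something is new, unique, unknown or untested is made for them only; others in the source may bear on it.

Measured so far in an assay on HEK293 cells for inhibition of melanin-concentrating hormone receptor 1 (Homo sapiens), read by radioligand binding; on this read-out higher numbers stand for weaker inhibition and lower numbers for stronger inhibition:

compound 1 `CN(C)c1nc(NCC2CCC(CNC(=O)c3ccc(Br)cc3OC(F)(F)F)CC2)nc2ccccc12` gives 1500 nM
compound 2 `CN(C)c1nc(N[C@H]2CC[C@@H](NC(=O)c3ccc(F)cc3)CC2)nc2ccccc12` gives 9.4 nM

Compound 2 stands lowest of the two numbers in this assay; its nearest neighbour, compound 1, sits far higher, and that gap lies well beyond the scatter of repeated measurements. Compound 1 and compound 2 differ in several places at once, so no single change can be read from that pair.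

The step now followed goes from compound 2 to compound 3 `Cc1cccc(C(=O)N[C@H]2CC[C@@H](Nc3nc(N(C)C)c4ccccc4n3)CC2)c1`, which has not yet been measured in this assay. The difference is 3-methylphenyl in place of 4-fluorophenyl on a carbonyl carbon. The rest of compound 2, the shared core and the linking amide, is kept unchanged.

Going by the values given here, no measured pair in this set isolates such an exchange of the aromatic ring on the carbonyl carbon, so the size of the step can only be guessed. A step in this assay from compound 2 to compound 3 of small size, if any beyond the scatter, is expected, most likely toward a somewhat higher number: a 2.1-fold higher number from compound 2 to compound 3 (0.33 log units; beyond the scatter). For compound 3 the estimate in this assay is 20 nM, with a range from 5 nM to 80 nM.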

Compound 3, half-maximal inhibitory concentration: 4.6 nM
Compound 3: the middle estimate sits 4.3-fold (0.64 log units) above what was measured; the measured number lies below the stated range.
By their numbers in this assay, from the lowest: compound 3; then compound 2; then compound 1.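

In this assay, going by these compounds alone, the exchange on the carbonyl carbon gives the first single-place step: a 2.0-fold lower number from compound 2 to compound 3 (0.31 log units; beyond the scatter), modest in size. At this place, 4-fluorophenyl is therefore not required for a low number, and a ring carrying no fluorine does at least as well when the shared core and linking amide are kept unchanged. Nothing in the data on hand bears on the reason for this step.

Within the data shown here, the single step changes three things at once: the fluorine goes, a methyl group enters, and the substituent's ring position changes, so only a comparison with unsubstituted phenyl, 4-methylphenyl or 3-fluorophenyl could separate their contributions. Going by these compounds, it also remains open whether the place on the carbonyl carbon accepts a ring containing nitrogen, such as pyridyl, or a ring bearing a methoxy group or a carboxylic acid, since both compounds in this step carry a six-membered aromatic ring of carbon only.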